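Swapping the Aryl Group on a Shared Kinase Inhibitor Core

This account rests on a few compounds, and the source may have more. Where it says the series, first, only, none or still open, it means among the compounds named here.

Compound 1 `CCc1cc(Nc2nc(N[C@@H](C)c3ccc(OC)cc3)nc3ccccc23)n[nH]1` gives 290 nM in an assay on isolated protein for inhibition of G protein-coupled receptor kinase 6 (Homo sapiens), read by scintillation counting, radiometric assay and 33P incorporation, with a stated time of 80 min, in the presence of a further agent that is not named here; a higher number here means a weaker inhibitor, a lower number a stronger inhibitor.
Compound 2 `CCc1cc(Nc2nc(NC3(c4ccc(Cl)cc4)CC3)nc3ccccc23)n[nH]1` gives 280 nM.

Compound 1 has the highest number of the two measured, but the gap to compound 2 lies within the scatter, so neither can be called the stronger inhibitor. Compound 3 `CCc1cc(Nc2nc(N[C@@H](C)c3cccc(F)c3)nc3ccccc23)n[nH]1` has not yet been measured. It differs from compound 1 in one place: 3-fluorophenyl in place of 4-methoxyphenyl on a saturated chain carbon bound to a nitrogen on an aromatic ring and a saturated chain carbon. Among the compounds with values here, with no measured step of this kind to lean on, the expected change in this assay is small, perhaps toward a weaker inhibitor but not clearly beyond the scatter, so the step of a 1.2-fold higher number from compound 1 to compound 3 (0.08 log units; within the scatter) is an estimate. Compound 3 is thus expected to give about 350 nM, within a range from 120 nM to 1000 nM.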

Compound 3, half-maximal inhibitory concentration: 340 nM
Compound 3: the middle estimate sits 1.0-fold (0.01 log units) above what was measured; the range from low to high includes it.
By their numbers in this assay, from the lowest: compounds 2, 1 and 3 (each within the scatter of the next).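

Within the data shown here, at this position on the chain carbon, 3-fluorophenyl in place of 4-methoxyphenyl gives the first single-place step in this assay: a 1.2-fold higher number from compound 1 to compound 3 (0.07 log units; within the scatter). The exchange removes the hydrogen-bond acceptor counted for 4-methoxyphenyl, yet the number stays within the scatter. No available evidence bears on this result. The step changes both the substituent and its place on the ring, so the two cannot be judged apart. As far as these compounds go, whether an amine or a carboxylic acid on this ring would move the number beyond the scatter remains open.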